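Removing the amide side chain of compound 2

The source may report more compounds than this note shows. Statements on the series, on what has been measured and on what is new or still open speak of the compounds shown alone.

In an assay on isolated protein for inhibition of Rho-associated protein kinase 1 (Homo sapiens) (a higher number here means a weaker inhibitor, a lower number a stronger inhibitor), compound 2 `COc1cccc(CN(CCCN(C)C)C(=O)c2cn(C)c3cc(-c4cn[nH]c4)ccc23)c1` gives 13 nM, the lowest of the two numbers read here. Compound 3 `COc1cccc(CN(CCCN2CCN(C)CC2)C(=O)c2c[nH]c3nc(-c4cn[nH]c4)ccc23)c1` gives 260 nM in this assay, a value beyond the scatter above that of compound 2. For compound 1 `COc1cccc(CNC(=O)c2c[nH]c3cc(-c4cn[nH]c4)ccc23)c1` this assay reports only a limit, < 1 nM, not a number. Compound 4 `COc1cccc(CNC(=O)c2cn(C)c3cc(-c4cn[nH]c4)ccc23)c1` differs from compound 2 by hydrogen in place of 3-(dimethylamino)propyl on an amide-type nitrogen, which leaves a secondary amide as in compound 1. Among the measured compounds shown here, no measured pair isolates this change. Because compound 1 carries the same secondary amide and sits at the limit (the limit of < 1 nM in this assay, at which 1 of the 3 values shown sits), compound 4 is expected to be a stronger inhibitor than compound 2, with a step of a 4.3-fold lower number from compound 2 to compound 4 (0.64 log units; beyond the scatter) beyond the scatter. Compound 4 is estimated at 3 nM, within 1 nM to 15 nM.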

Compound 4, half-maximal inhibitory concentration: < 1 nM
Compound 4 was reported as a limit (the forecaster's own chance of this, stated with the estimate: 20%); middle value at least 3.0-fold (0.47 log units) from the limit.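

In this assay, hydrogen in place of 3-(dimethylamino)propyl on the amide-type nitrogen gives an at least 13-fold lower number from compound 2 to compound 4 (1.11 log units; beyond the scatter), the only readable step at this position among the compounds shown. Compound 4 gives < 1 nM, which is a limit and not a number. The step from compound 1 to compound 4, methyl in place of hydrogen on the aromatic nitrogen, cannot be read, because both compounds stand at the limit: the limit of < 1 nM in this assay, at which 2 of the 4 values shown sit.

From the compounds shown here alone, it remains open whether a shorter chain such as ethyl, or a chain ending in a carboxylic acid, on this amide-type nitrogen would preserve this inhibition.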